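The compounds below may be only part of what the source reports. "The series", "measured", "known", "first", "only" and "open" are said of these compounds alone.

Measured compounds:
compound 1, `Clc1ccc(OCc2nc3ccccc3n2CCN2CCCCC2)cc1`, > 100000 nM in an assay on isolated protein for binding affinity to Neuropeptide Y receptor type 1 (Homo sapiens); on this read-out higher numbers stand for weaker inhibition and lower numbers for stronger inhibition
compound 2, `Clc1ccc(OCc2nc3c(OCCC4CCCNC4)cccc3n2CCCC2CCCNC2)cc1`, 18 nM in this assay
compound 3, `Clc1ccc(OCc2nc3ccccc3n2CCC2CCCCN2)cc1`, 7860 nM in this assay

The value of compound 1 is a limit of this assay, not a number, as noted in the limit of > 100000 nM in this assay, at which 1 of the 3 values shown sits. Of the two numbers, compound 2 has the lowest, and compound 3 is its nearest neighbour, well beyond the scatter.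

Compound 4, `Clc1ccc(OCc2nc3c(OCCCN4CCCCC4)cccc3n2CCCC2CCCNC2)cc1`, has not yet been measured in this assay. It differs from compound 2 by (piperidin-1-yl)methyl in place of piperidin-3-yl on a saturated chain carbon, two bonds along the chain from an oxygen on an aromatic ring.

Among the measured compounds shown here, one measured step bears on this: an at least 12-fold lower number from compound 1 to compound 3 (1.10 log units; beyond the scatter). There the attachment of the ring moved from its nitrogen to a ring carbon, and the number fell; the change in compound 4 runs the opposite way, from a carbon-attached ring carrying a hydrogen-bond donor to a nitrogen-attached one without, though at a different chain, the one that hangs from the aromatic oxygen. Compound 4 is therefore expected to give a higher number than compound 2, by a step of moderate size, a 5.0-fold higher number from compound 2 to compound 4 (0.70 log units; beyond the scatter). Compound 4 is estimated at 90 nM, between 20 nM and 500 nM.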

Compound 4, inhibition constant: 1.7 nM
Compound 4: the middle estimate sits 53-fold (1.72 log units) above what was measured; the measured number lies below the stated range.
By their numbers in this assay, from the lowest: compound 4; then compound 2; then compound 3. At a limit, above all of these: compound 1.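

In this assay, the change on this saturated chain carbon, two bonds along the chain from an oxygen on an aromatic ring, gives an 11-fold lower number from compound 2 to compound 4 (1.02 log units; beyond the scatter), so the hydrogen-bond donor of piperidin-3-yl is not needed here for a low number, and the group that enters, without a donor, goes with the stronger inhibition. The earlier compounds shown here showed only the other chain, the one on the aromatic nitrogen, where compound 1 and compound 3 placed the ring attached through its nitrogen on the weaker side, so attachment through the ring nitrogen does not point the same way on both chains. Nothing among the measurements shown accounts for this step.

The change from compound 2 to compound 4 alters the ring attachment and the length of the chain together, so the compounds shown leave open which of the two goes with the lower number, a question that 2-(piperidin-1-yl)ethoxy or 3-(piperidin-3-yl)propoxy in this place would separate. They also leave open whether the ring nitrogen can give way to a morpholine or to an open-chain diethylamino group on this propoxy chain.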